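A few compounds are considered here, and "the series" means these few. Any claim that something is new, unique, unknown or untested is made for them only; others in the source may bear on it.

Measured compounds:
- compound 1 `COc1ccc(OC(=O)c2cn(-c3ccccc3)nc2-c2ccncc2)cc1` — in a functional assay on MCF7 cells (Homo sapiens) for cytotoxicity, read by MTT assay, with a stated time of 48 h (on this read-out lower numbers stand for stronger inhibition and higher numbers for weaker inhibition), compound 1 reaches only the assay limit, > 100000 nM.
- compound 2 `CC(C)c1cccc(OC(=O)c2cn(-c3ccccc3)nc2-c2ccncc2)c1` — in this assay compound 2 gives "nd(insoluble)" (no result reported).
- compound 3 `CC(C)(C)c1ccc(OC(=O)c2cn(-c3ccccc3)nc2-c2ccncc2)cc1` — in this assay compound 3 gives 32300 nM.

Going by the values given here, compound 3 thus holds the only number in this assay; compound 1 stands at a limit and compound 2 has no result. Among the compounds with values here, the single measured step, an at least 3.0-fold lower number from compound 1 to compound 3 (0.49 log units; beyond the scatter), is at least modest and is bounded by the limit of > 100000 nM in this assay, at which 1 of the 3 values shown sits; it also varies the aryl group on the ester oxygen. Compound 4 `O=C(Oc1ccc2ccccc2c1)c1cn(-c2ccccc2)nc1-c1ccncc1` differs from compound 3 by naphthalen-2-yl in place of 4-(tert-butyl)phenyl on an oxygen next to a carbonyl group. Within the data shown here, no measured step covers a fused aromatic ester group, so the step is expected to be small or within the scatter, a 1.1-fold lower number from compound 3 to compound 4 (0.03 log units; within the scatter). Compound 4 is estimated at 30000 nM, with a range from 8000 nM to 100000 nM, and a limit-only result remains possible.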

Compound 4, half-maximal inhibitory concentration: 44500 nM
Compound 4: the middle estimate sits 1.5-fold (0.17 log units) below what was measured; low and high end bracket the measured number.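

At this position, on an oxygen next to a carbonyl group, 4-(tert-butyl)phenyl and naphthalen-2-yl cannot be told apart in this assay: the change gives a 1.4-fold higher number from compound 3 to compound 4 (0.14 log units; within the scatter). A second aromatic ring in place of the tert-butyl group therefore leaves the number within the scatter. Going from 4-methoxyphenyl to naphthalen-2-yl gives an at least 2.2-fold lower number from compound 1 to compound 4 (0.35 log units; beyond the scatter), and the true size of this step stays unknown, as it rests on a limit: the limit of > 100000 nM in this assay, at which 1 of the 4 values shown sits.

Going by these compounds, whether an amine or a carboxylic acid on this aryl group would shift the number remains open. Also open, on these data alone, is how changes to the shared core would read.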